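The compounds below may be only part of what the source reports. "The series", "measured", "known", "first", "only" and "open" are said of these compounds alone.

Measured compounds:
compound 1, `O=C(CN1CCCC1)N1CCC(NS(=O)(=O)c2cc(S(=O)(=O)c3ccccc3)ccc2C(F)(F)F)CC1`, giving 190 nM in a functional assay on U2OS cells for antagonist activity at proto-oncogene Wnt-3 (Homo sapiens), read by a luciferase reporter, with a stated time of 18 h; a higher number here means that more compound is needed for the effect, a lower number that less compound is needed;
compound 2, `CC(C)C(=O)N1CCC[C@H]1C(=O)N1CCC(NS(=O)(=O)c2cc(S(=O)(=O)c3ccccc3)ccc2C(F)(F)F)CC1`, giving 90 nM;
compound 3, `CC(C)(C)CC(=O)N1CCC[C@H]1C(=O)N1CCC(NS(=O)(=O)c2cc(S(=O)(=O)c3ccccc3)ccc2C(F)(F)F)CC1`, giving 120 nM.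

On these numbers compound 3 sits second of three, close to compound 2 and within the scatter of both neighbours. Compound 4, `CN(C)C(=O)N1CCC[C@H]1C(=O)N1CCC(NS(=O)(=O)c2cc(S(=O)(=O)c3ccccc3)ccc2C(F)(F)F)CC1`, differs from compound 3 by dimethylamino in place of neopentyl on a carbonyl carbon. Among the compounds with values here, the steps that bear on this are a 1.3-fold higher number from compound 2 to compound 3 (0.12 log units; within the scatter) and a 1.6-fold lower number from compound 1 to compound 3 (0.20 log units; within the scatter), both within the scatter, while a 2.1-fold lower number from compound 1 to compound 2 (0.32 log units; beyond the scatter) was modest. Changes at this carbonyl carbon have so far moved this assay little, so compound 4 is expected to stay near compound 3, with a 1.1-fold lower number from compound 3 to compound 4 (0.04 log units; within the scatter). Compound 4 is therefore estimated at 110 nM, in the range 50 nM to 250 nM.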

Compound 4, half-maximal effective concentration: 160 nM
Estimate against measurement, compound 4: 1.5-fold (0.16 log units) below; low and high end bracket the measured number.
By their numbers in this assay, from the lowest: compounds 2, 3, 4 and 1 (each within the scatter of the next, the first and the last beyond it).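

With dimethylamino, which brings a nitrogen where neopentyl holds only carbon, on the carbonyl carbon, this assay gives a step within the scatter (a 1.3-fold higher number from compound 3 to compound 4 (0.12 log units; within the scatter)), and the comparisons with the other two compounds also stay within it (a 1.8-fold higher number from compound 2 to compound 4 (0.25 log units; within the scatter); a 1.2-fold lower number from compound 1 to compound 4 (0.07 log units; within the scatter)). Within the data shown here, this carbonyl carbon has now carried isopropyl, neopentyl and dimethylamino with no step among the three beyond the scatter. No measurement here offers an explanation for this.

Going by these compounds, whether a carboxylic acid, a piperidine or a longer chain on this carbonyl carbon would give a step beyond the scatter remains open.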